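Removing a Methoxy From a Compound at the Assay Limit

The source may report more compounds than this note shows. Statements on the series, on what has been measured and on what is new or still open speak of the compounds shown alone.

Compound 2 `COc1ccc2[nH]c(=O)c(-c3nc4cc(Cl)ccc4[nH]3)cc2c1` and compound 1 `O=c1[nH]c2ccccc2cc1-c1nc2cc([N+](=O)[O-])ccc2[nH]1` share a core and were both tested in a functional assay on BEL-7404 cells for cytotoxicity against BEL-7404 tumor cell line (Homo sapiens), read by MTT assay, with a stated time of 48 h; on this read-out lower numbers stand for stronger inhibition and higher numbers for weaker inhibition. In this assay compound 1 gives only a limit, > 100000 nM, and not a number. Compound 2 likewise reaches only a limit in this assay, > 100000 nM, rather than a measured number. Within the data shown here, compound 2 therefore stands at the edge of what the assay can report, and the one other value shown sits at the same place: the limit of > 100000 nM in this assay, at which 2 of the 2 values shown sit. Among the measured compounds shown here, no step between two measured compounds that differ in one place is available, so nothing here shows how far a single change moves the read-out.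

Compound 3 `O=c1[nH]c2ccccc2cc1-c1nc2cc(Cl)ccc2[nH]1` is the compound still to be measured. It differs from compound 2 in one place: hydrogen in place of methoxy on an aromatic carbon. With both measured compounds sitting at the limit, no direction is indicated for this change in this assay, and the expected step, a step that the limit leaves unreadable from compound 2 to compound 3, is none beyond the usual scatter. Compound 3 is therefore expected to give 150000 nM, within 30000 nM to 1000000 nM, with a strong chance that the assay again reports only a limit.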

Compound 3, half-maximal inhibitory concentration: 16500 nM
For compound 3 the middle estimate is 9.1-fold (0.96 log units) above the measured one; measured number below the stated range.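

Among these compounds, compound 3 is the only one of the three that gives a real number in this assay, so this position on the ring now shows an effect that the earlier compounds could not show. Hydrogen in place of methoxy gives an at least 6.0-fold lower number from compound 2 to compound 3 (0.78 log units; beyond the scatter), and on the other side of the core, chloro in place of nitro gives an at least 6.0-fold lower number from compound 1 to compound 3 (0.78 log units; beyond the scatter), so each of these two single changes is enough to bring a compound from the limit to a measurable value. Both steps are minimum sizes only, and their true sizes cannot be read, because each starts from a compound that gives a limit and not a number: the limit of > 100000 nM in this assay, at which 2 of the 3 values shown sit.

As far as these compounds go, what remains open is whether hydrogen is special at the methoxy position or whether another group there, such as a fluoro, an amine or a longer chain like ethoxy, would also give a measurable value. The compounds shown also leave open how the number would move if the chloro were replaced by a group such as a carboxylic acid, since only chloro and nitro appear at that place.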